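One Ring Swap on a Shared Core, Result Pending

A few compounds are considered here, and "the series" means these few. Any claim that something is new, unique, unknown or untested is made for them only; others in the source may bear on it.

Compound 1, `Nc1ccc(C(=O)/C=C/c2ccco2)cc1`: 30%
Compound 2, `O=C(CBr)Nc1ccc(C(=O)/C=C/c2ccc(Cl)cc2)cc1`: 54%

Within the data shown here, in a functional assay on the whole organism (strain albino) for inhibition, with Rattus norvegicus as the target, read by paw edema, with stated times of 30 min and 5 h, at a dose of 100 mg/kg by the oral route (on this read-out higher numbers stand for more inhibition at the one dose given (going by the name of the read-out) and lower numbers for less inhibition), compound 2 gives 54%, the higher of the two numbers measured so far. Compound 1 gives 30%, a gap beyond the scatter. Compound 3, `O=C(CBr)Nc1ccc(C(=O)/C=C/c2ccco2)cc1`, differs from compound 2 by furan-2-yl in place of 4-chlorophenyl on a double-bonded chain carbon bound to a double-bonded chain carbon. Among the measured compounds shown here, no measured pair isolates this change, since compound 1 and compound 2 differ in two places. The step from compound 2 to compound 3 is expected to be a number 12 percentage points lower from compound 2 to compound 3 (beyond the scatter), a moderate fall, as compound 1, which also carries furan-2-yl, sits at 30%. Compound 3 is estimated at 42%, with a range from 25% to 60%.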

Compound 3, a percentage reported as inhibition, in the whole organism at one dose (the size of the read-out at that dose, not a potency): 25%
Estimate against measurement, compound 3: 17 percentage points above; measured number inside the range.
By their numbers in this assay, from the lowest: compounds 3 and 1 (each within the scatter of the next); then compound 2.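

In this assay, the swap can now be read on its own: with the (bromomethyl)carbonyl group held constant, the change gives a number 29 percentage points lower from compound 2 to compound 3 (beyond the scatter) and furan-2-yl does not match 4-chlorophenyl at this position. With furan-2-yl held constant, (bromomethyl)carbonyl in place of hydrogen on the nitrogen gives a number 5 percentage points lower from compound 1 to compound 3 (within the scatter) and so shows no change beyond the scatter. Nothing measured here explains either result. Open, on these data alone, is whether an unsubstituted phenyl or a thiophen-2-yl would stand closer to 4-chlorophenyl or to furan-2-yl. Also open, as far as these compounds go, is whether an acetyl group on the nitrogen would read differently alongside 4-chlorophenyl.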